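This account rests on a few compounds, and the source may have more. Where it says the series, first, only, none or still open, it means among the compounds named here.

Measured so far:
compound 1 `C[C@@H](O[C@@H]1CN(C=O)C[C@H]1c1ccc(F)cc1)c1cc(C(F)(F)F)cc(C(F)(F)F)c1`, in an assay on CHO cells for displacement of a labelled ligand from Substance-P receptor (Homo sapiens) (a higher number here means a weaker inhibitor, a lower number a stronger inhibitor), giving 0.24 nM
compound 2 `CCC(=O)N1C[C@@H](O[C@H](C)c2cc(C(F)(F)F)cc(C(F)(F)F)c2)[C@H](c2ccc(F)cc2)C1`, giving 0.09 nM
compound 3 `CC(C)C(=O)N1C[C@@H](O[C@H](C)c2cc(C(F)(F)F)cc(C(F)(F)F)c2)[C@H](c2ccc(F)cc2)C1`, giving 0.15 nM

Compound 3 holds the second highest of these three numbers: a 1.6-fold lower number from compound 1 to compound 3 (0.20 log units; within the scatter), and a 1.7-fold higher number from compound 2 to compound 3 (0.22 log units; within the scatter), both within the scatter. Compound 4 `CC(=O)N1CCC(C(=O)N2C[C@@H](O[C@H](C)c3cc(C(F)(F)F)cc(C(F)(F)F)c3)[C@H](c3ccc(F)cc3)C2)CC1` arises from compound 3 by 1-acetylpiperidin-4-yl in place of isopropyl on a carbonyl carbon. Among the compounds with values here, the steps that bear on this change all alter what sits on the same carbonyl carbon: a 2.7-fold lower number from compound 1 to compound 2 (0.43 log units; beyond the scatter), a 1.6-fold lower number from compound 1 to compound 3 (0.20 log units; within the scatter) and a 1.7-fold higher number from compound 2 to compound 3 (0.22 log units; within the scatter). Only one of them is modest and beyond the scatter; the others are not. Nothing measured here covers a group as large as the entering one, so compound 4 is expected to show no step beyond the scatter, a 1.3-fold higher number from compound 3 to compound 4 (0.12 log units; within the scatter). Compound 4 is therefore estimated at 0.2 nM, between 0.06 nM and 0.7 nM.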

Compound 4, half-maximal inhibitory concentration: 0.07 nM
The estimate for compound 4 lay 2.9-fold (0.46 log units) above the measured number; the range from low to high includes it.
By their numbers in this assay, from the lowest: compounds 4, 2, 3 and 1 (each within the scatter of the next, the first and the last beyond it).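

At this carbonyl carbon, a group as large as 1-acetylpiperidin-4-yl, with its six-membered non-aromatic ring, is tolerated without loss: a 2.1-fold lower number from compound 3 to compound 4 (0.33 log units; beyond the scatter) and a 3.4-fold lower number from compound 1 to compound 4 (0.54 log units; beyond the scatter) are both beyond the scatter, while a 1.3-fold lower number from compound 2 to compound 4 (0.11 log units; within the scatter) stays within it. Among these compounds, then, the small groups did not mark a limit on size at this position. Nothing here bears on why the larger group compares as it does with isopropyl. Whether the ring or its acetyl carries the step stays open, since the compounds shown do not separate them. Also open, going by these compounds, is how a free piperidine amine, or a carboxylic acid in place of the acetyl, would behave.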